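Trifluoromethoxy on the hydrazone ring: a smaller guess

The source may hold more compounds than are shown below. What is called first, only, known or untested is meant among the compounds shown, and "the series" means these compounds.

Compound 1 `Cn1c(=O)c(=O)n(C2CCCC2)c2nc(N/N=C/c3ccccc3)ncc21` gives 48200 nM in a functional assay on PC-3 cells (Homo sapiens) for antiproliferative activity, read by MTT assay (a lower number here means a stronger inhibitor, a higher number a weaker inhibitor), the higher of the two numbers measured here. Compound 2 `Cn1c(=O)c(=O)n(C2CCCC2)c2nc(N/N=C/c3cc([N+](=O)[O-])ccc3Cl)ncc21` gives 9260 nM, and the change of a 5.2-fold lower number from compound 1 to compound 2 (0.72 log units; beyond the scatter) shows that altering this ring can matter. Compound 3 `Cn1c(=O)c(=O)n(C2CCCC2)c2nc(N/N=C/c3ccc(OC(F)(F)F)cc3)ncc21` differs from compound 1 by trifluoromethoxy in place of hydrogen on an aromatic carbon. For the measured compounds named here, only that one step bears on this change, and it involved a different substituent, so a smaller move in the same direction is expected. Compound 3 is therefore estimated at 22000 nM, with a range from 7000 nM to 60000 nM. The expected step is a 2.2-fold lower number from compound 1 to compound 3 (0.34 log units; beyond the scatter).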

Compound 3, half-maximal inhibitory concentration: 7180 nM
The estimate for compound 3 lay 3.1-fold (0.49 log units) above the measured number; measured number inside the range.
By their numbers in this assay, from the lowest: compounds 3 and 2 (each within the scatter of the next); then compound 1.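

With trifluoromethoxy in place of hydrogen, para to a large group, this assay shows a 6.7-fold lower number from compound 1 to compound 3 (0.83 log units; beyond the scatter), so a single substituent on this ring is enough to shift the number beyond the scatter. Compound 3 and compound 2 lie within the scatter of each other, so their quite different ring substituents cannot be ranked. No measurement here offers an explanation for this step.

From the compounds shown here alone, whether a methoxy group, an amine or a carboxylic acid on the same ring carbon would give a similar step remains open. So does whether trifluoromethoxy would act alike elsewhere on the ring.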